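Chain unsaturation in the compound 1 series

The compounds below may be only part of what the source reports. "The series", "measured", "known", "first", "only" and "open" are said of these compounds alone.

Values in a functional assay on the whole organism (strain Hartley) for inhibition, with Cavia porcellus as the target, with stated times of 15 min and 2 min (a higher number here means that more compound is needed for the effect, a lower number that less compound is needed), so far:
compound 1 `CCCCC1([C@@H](O)/C=C/C2[C@H](O)CC(=O)[C@@H]2CCCCCCC(=O)O)CCC1` gives 0.03 mg/kg
compound 2 `CCCCC1([C@H](O)/C=C/C2CCC(=O)[C@@H]2CCCCSCC(=O)OCC)CCC1` gives 0.909 mg/kg
compound 3 `CCCCC1([C@H](O)/C=C/C2CCC(=O)[C@@H]2C/C=C\CCCC(=O)O)CCC1` gives 0.0242 mg/kg

Compound 1 stands within the scatter of compound 3 and beyond the scatter on the lower side of compound 2 in these numbers. Compound 4 (`CCCCC1([C@@H](O)/C=C/C2[C@H](O)CC(=O)[C@@H]2C/C=C\CCCC(=O)O)CCC1`) carries 5-carboxypent-1-en-1-yl in place of 5-carboxypentyl on a saturated chain carbon bound to a saturated ring carbon. Among the compounds with values here, no measured pair isolates this change. Compound 3, which also differs elsewhere, bears the same chain and gives 0.0242 mg/kg in this assay so no step beyond the scatter is expected. The step expected is a 1.5-fold lower number from compound 1 to compound 4 (0.18 log units; within the scatter) and lies within the scatter. The estimate for compound 4 is 0.02 mg/kg with an expected range from 0.007 mg/kg to 0.06 mg/kg for the coming measurement.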

Compound 4, dose for half-maximal effect: 0.032 mg/kg
Estimate against measurement, compound 4: 1.6-fold (0.20 log units) below; low and high end bracket the measured number.
By their numbers in this assay, from the lowest: compounds 3, 1 and 4 (each within the scatter of the next); then compound 2.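

In this assay, within the data shown here, a 1.1-fold higher number from compound 1 to compound 4 (0.03 log units; within the scatter) is the only step that isolates a single change, and it lies within the scatter. Among these compounds, on a saturated chain carbon bound to a saturated ring carbon, 5-carboxypent-1-en-1-yl and 5-carboxypentyl therefore cannot be told apart in this assay, so the added chain double bond carries no visible penalty or gain here, which the earlier compounds, differing in several places, could not show. No evidence on hand bears on why this is so.

Still open, as far as these compounds go, is whether a longer chain carrying the same double bond would keep such a number. The same applies to a tetrazole in place of the carboxylic acid.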